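The source may report more compounds than this note shows. Statements on the series, on what has been measured and on what is new or still open speak of the compounds shown alone.

Measured so far: compound 1 `C[C@H](NC(=O)c1nnn(Cc2ccc(C(F)(F)F)cc2)c1C(F)(F)F)c1ccc(C(=O)O)cc1`, compound 2 `C[C@H](NC(=O)c1cn(Cc2ccc(C(F)(F)F)cc2)nn1)c1ccc(C(=O)O)cc1` and compound 3 `C[C@H](NC(=O)c1c(C(F)(F)F)nnn1Cc1ccc(F)cc1)c1ccc(C(=O)O)cc1`.

In a functional assay on CHO cells for antagonist activity at prostaglandin E2 receptor EP4 subtype (Homo sapiens), read by calcium flux, with a stated time of 15 min (a higher number here means a weaker inhibitor, a lower number a stronger inhibitor), compound 1 gives only a limit, > 10000 nM. Compound 2 likewise gives only a limit in this assay, > 10000 nM. Within the data shown here, compound 3 gives the single number of the set in this assay, 2320 nM. The step that the two limits leave unreadable from compound 1 to compound 2 cannot be read, since both of its ends sit at the limit of > 10000 nM in this assay, at which 2 of the 3 values shown sit.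

Compound 4 `C[C@H](NC(=O)c1c(C(F)(F)F)nnn1Cc1ccc(C(F)(F)F)cc1)c1ccc(C(=O)O)cc1` has not been measured. It differs from compound 3 in one place: trifluoromethyl in place of fluoro on an aromatic carbon. Among the measured compounds shown here, the only measured pair that touches this position, compound 1 against compound 2, exchanges trifluoromethyl for hydrogen there, and its size is hidden by the limits, so no measured step gives a readable guide for the size or direction of this change. The expectation for compound 4 is therefore a step of a 1.2-fold lower number from compound 3 to compound 4 (0.06 log units; within the scatter) within the scatter, with no direction that the data can support. Compound 4 is estimated in this assay at 2000 nM, within a range from 600 nM to 7000 nM.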

Compound 4, half-maximal inhibitory concentration: 225 nM
For compound 4 the middle estimate is 8.9-fold (0.95 log units) above the measured one, and the stated range ends above it.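

In this assay, trifluoromethyl in place of fluoro on the aromatic carbon para to a large group gives a 10-fold lower number from compound 3 to compound 4 (1.01 log units; beyond the scatter), so this position now has a readable step, one beyond the scatter. Among these compounds, the only earlier pair touching this position, compound 1 and compound 2, cannot be read, as both of its ends are limits: the limit of > 10000 nM in this assay, at which 2 of the 4 values shown sit. The new step is a single pair on one core and gives a size and a direction, not a cause.

As far as these compounds go, whether a chlorine atom, a methoxy group or a nitrile on this aromatic carbon would read closer to compound 3 or to compound 4 remains open. Also open, from the compounds shown here alone, is whether the exchange of fluoro for trifluoromethyl would give a similar step on the core of compound 2.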